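The source may hold more compounds than are shown below. What is called first, only, known or untested is meant among the compounds shown, and "the series" means these compounds.

Compound 1 `CCCc1nc(-c2ccccc2)c(CNCCN2CCN(c3ccccc3Cl)CC2)o1` gives 60.1% in an assay on HEK293 cells for inhibition of Voltage-dependent T-type calcium channel subunit alpha-1G (Homo sapiens), read by fluorescence, tested at 10 uM; on this read-out higher numbers stand for more inhibition at the one concentration tested (going by the name of the read-out) and lower numbers for less inhibition. Compound 2 `CCCc1nc(-c2ccccc2)c(CNCCCN2CCN(c3ccccc3F)CC2)o1` gives 54.4%. Compound 3 `CCCc1nc(-c2ccccc2)c(CNCCCN2CCN(c3cccc(C)c3)CC2)o1` gives 47.8%.

Compound 1 holds the highest of the three numbers, but compound 2 sits within the scatter of it; only compound 3 lies beyond. For the measured compounds named here, the single measured exchange of the aryl group on the ring nitrogen is a number 6.6 percentage points lower from compound 2 to compound 3 (within the scatter), a step within the scatter, though taken on a different pair of compounds. Compound 4 `CCCc1nc(-c2ccccc2)c(CNCCN2CCN(c3cccc(C)c3C)CC2)o1` differs from compound 1 by 2,3-dimethylphenyl in place of 2-chlorophenyl on an amine nitrogen in a ring. Going by the values given here, with only that one small step to go on, no change beyond the scatter is expected, and a slight drop is estimated, a number 7.1 percentage points lower from compound 1 to compound 4 (within the scatter). Compound 4 is therefore expected at 53%, between 36% and 68%.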

Compound 4, a percentage reported as inhibition, at one concentration (the size of the read-out at that concentration, not a potency): 66.7%
Compound 4: the middle estimate sits 13.7 percentage points below what was measured, within the range that was stated.
By their numbers in this assay, from the lowest: compounds 3, 2, 1 and 4 (each within the scatter of the next, the first and the last beyond it).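

In this assay the exchange on the ring nitrogen gives a number 6.6 percentage points higher from compound 1 to compound 4 (within the scatter) and so shows that 2,3-dimethylphenyl can stand in place of 2-chlorophenyl with no change that can be told from the scatter. This is a second aryl exchange at this place that stays within the scatter, now on the pair with the shorter chain. Nothing at hand bears on why this exchange behaves as it does. The compounds shown leave open what a simple methyl group or a methoxyphenyl group would give on this ring nitrogen.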